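Swapping Chloro for Bromo on the Amide-Side Ring

The source may report more compounds than this note shows. Statements on the series, on what has been measured and on what is new or still open speak of the compounds shown alone.

Compound 1 `Cc1ccccc1NC(=O)c1cc(C)n(-c2cccc(C(F)(F)F)c2)n1` and compound 2 `Cc1cc(C(=O)Nc2cccc(Cl)c2)nn1-c1cccc(C(F)(F)F)c1` share one core and differ only in the ring on the amide nitrogen. In an assay on HEK293 cells for binding affinity to Neuropeptide Y receptor type 5 (Homo sapiens), read by radioligand binding (on this read-out higher numbers stand for weaker inhibition and lower numbers for stronger inhibition), compound 1 gives 573 nM, and compound 2 gives 520 nM. The step of a 1.1-fold lower number from compound 1 to compound 2 (0.04 log units; within the scatter) leaves the two side by side, so compound 2 has no clear standing apart from compound 1. Compound 3 `Cc1cc(C(=O)Nc2cccc(Br)c2)nn1-c1cccc(C(F)(F)F)c1` is not yet measured and carries bromo in place of chloro on an aromatic carbon. For the measured compounds named here, no measured step tests a chloro-to-bromo exchange, and the only known step stayed within the scatter, so for compound 3 a shift of a 1.2-fold lower number from compound 2 to compound 3 (0.06 log units; within the scatter) is expected, within the scatter. Compound 3 is estimated at 450 nM, ranging from 200 nM to 1100 nM.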

Compound 3, half-maximal inhibitory concentration: 359 nM
The estimate for compound 3 lay 1.3-fold (0.10 log units) above the measured number; the range from low to high includes it.
By their numbers in this assay, from the lowest: compounds 3, 2 and 1 (each within the scatter of the next).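

Bromo in place of chloro on the aromatic carbon gives a 1.4-fold lower number from compound 2 to compound 3 (0.16 log units; within the scatter) in this assay and so leaves no clear change, which shows that this position takes either halogen with the number staying within the scatter. Set against the 2-methylphenyl amide, the 3-bromophenyl group gives a 1.6-fold lower number from compound 1 to compound 3 (0.20 log units; within the scatter) and also stays within the scatter, so the three amide-side rings cannot be told apart. Nothing available bears on why these numbers fall as they do.

Going by these compounds, whether an amine, a carboxylic acid or a methoxy group on this ring would move the number beyond the scatter remains open.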